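One Methyl Group, Tested Twice in Mice

A few compounds are considered here, and "the series" means these few. Any claim that something is new, unique, unknown or untested is made for them only; others in the source may bear on it.

Compound 1 `CC(=O)N(C)C(C)C#CCn1cncc1C` and compound 2 `CC(=O)N(C)CC#CCn1cncc1C` share one core, while compound 3 `CCOC(=O)N(C)CC#CCN1CCCC1` and compound 4 `CCOC(=O)N(C)C(C)C#CCN1CCCC1` share another; the difference between the two cores is not broken down here. In a functional assay on the whole organism for antagonist activity, with Mus musculus as the target (on this read-out lower numbers stand for an effect already at smaller amounts and higher numbers for an effect only at larger amounts of compound), compound 2 gives 6.6 mg/kg. In this assay compound 1 gives 1.1 mg/kg. The step of a 6.0-fold lower number from compound 2 to compound 1 (0.78 log units; beyond the scatter) comes from the change (methyl in place of hydrogen on a saturated chain carbon bound to an amide-type nitrogen and a triple-bonded carbon). For compound 3 the read-out is not a number but a limit, > 100 mg/kg, which is the limit of > 100 mg/kg in this assay, at which 1 of the 3 values shown sits. The same change is now made from compound 3 to compound 4, namely (methyl in place of hydrogen on a saturated chain carbon bound to an amide-type nitrogen and a triple-bonded carbon), and the place is described in the same words in both pairs. Among these four compounds the change occurs only twice, so the earlier step is the sole guide. Because compound 3 gives > 100 mg/kg, the starting point is itself a limit, and it is unclear whether a gain of the size seen earlier would carry compound 4 into the range where a number is reported. Compound 4 is therefore expected near 50 mg/kg, the estimated step of an at least 2.0-fold lower number from compound 3 to compound 4 (0.30 log units; that floor lies within the scatter) lying between 12 mg/kg and 300 mg/kg.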

Compound 4, dose for half-maximal effect: 97 mg/kg
For compound 4 the middle estimate is 1.9-fold (0.29 log units) below the measured one; low and high end bracket the measured number.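

Carrying the methyl in place of hydrogen from one core to the other gives a comparison that can be read only in part: the same change on two cores in this assay, a 6.0-fold lower number (0.78 log units; beyond the scatter) from compound 2 to compound 1 and an at least 1.0-fold lower number (0.01 log units; that floor lies within the scatter) from compound 3 to compound 4; the limit leaves it open whether they differ. On the second core the reading is an at least 1.0-fold lower number from compound 3 to compound 4 (0.01 log units; that floor lies within the scatter), which is a floor and not a size, so no gain beyond the scatter is shown there, yet a gain as large as that on the first core is not ruled out either. Compound 3 stands at a limit and not at a number, so the two steps cannot be set against each other in size, and the data neither confirm nor refute that the change carries over: the limit of > 100 mg/kg in this assay, at which 1 of the 4 values shown sits.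

The compounds shown leave open how an ethyl group or a longer chain, on a saturated chain carbon bound to an amide-type nitrogen and a triple-bonded carbon, would compare with methyl. They also leave open how the same methyl would read in this assay on a core whose parent gives a number and not a limit.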